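Swapping a Cyclopentyl Ketone for a Piperidine Urea

The source may report more compounds than this note shows. Statements on the series, on what has been measured and on what is new or still open speak of the compounds shown alone.

Among the measured compounds shown here, in an ADME assay on Caco-2 cells (Homo sapiens) for permeability, in the apical to basolateral direction (a higher number here means that the compound crosses the layer faster, a lower number that the compound crosses the layer more slowly), compound 1 `Cn1cncc1CN1CC(N(CC2CCN(C(=O)C3CCCC3)CC2)S(=O)(=O)c2ccccn2)Cc2cc(C#N)ccc21` gives 0.5 10^-6 cm/s, the lower of the two numbers measured so far. Compound 2 `Cn1cncc1CN1CC(N(CC2CCN(C(=O)OC(C)(C)C)CC2)S(=O)(=O)c2ccccn2)Cc2cc(C#N)ccc21` gives 15.5 10^-6 cm/s, and the step of a 31-fold higher number from compound 1 to compound 2 (1.49 log units; beyond the scatter) shows how much a single change on a carbonyl carbon can move this read-out. Compound 3 `Cn1cncc1CN1CC(N(CC2CCN(C(=O)N3CCCCC3)CC2)S(=O)(=O)c2ccccn2)Cc2cc(C#N)ccc21` has not yet been measured; it differs from compound 1 by piperidin-1-yl in place of cyclopentyl on a carbonyl carbon. For the measured compounds named here, the only measured step that bears on this change is a 31-fold higher number from compound 1 to compound 2 (1.49 log units; beyond the scatter), which also replaced the cyclopentyl on the same carbonyl carbon, and that step was large and upward. A piperidin-1-yl is not a tert-butoxy, so the same size cannot simply be assumed, but an upward move is the more likely outcome than none. Compound 3 is therefore expected to show a 6.0-fold higher number from compound 1 to compound 3 (0.78 log units; beyond the scatter). The estimate for compound 3 in this assay is 3 10^-6 cm/s, with a range from 0.6 10^-6 cm/s to 12 10^-6 cm/s.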

Compound 3, apparent permeability: 0.6 10^-6 cm/s
For compound 3 the middle estimate is 5.0-fold (0.70 log units) above the measured one, and the stated range covers the measured number.
By their numbers in this assay, from the lowest: compounds 1 and 3 (each within the scatter of the next); then compound 2.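

Replacing the cyclopentyl on this carbonyl carbon does not always raise the number in this assay: piperidin-1-yl gives a 1.2-fold higher number from compound 1 to compound 3 (0.08 log units; within the scatter) and so stays within the scatter. Among the compounds shown here, exchanging tert-butoxy for piperidin-1-yl on the same carbon gives a 26-fold lower number from compound 2 to compound 3 (1.41 log units; beyond the scatter) and leaves tert-butoxy as the only group of the three with a high number. At this position, then, the read-out depends strongly on which group sits on the carbonyl carbon, although one ring in place of another makes no clear difference here.

No measurement available here explains why these groups behave so differently. From the compounds shown here alone, it remains open whether the high number is unique to tert-butoxy or would also appear with a smaller methoxy or a dimethylamino group on the same carbonyl carbon.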